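The compounds below may be only part of what the source reports. "The series", "measured", "known", "first", "only" and "open" are said of these compounds alone.

In a functional assay on HCT-116 cells (Homo sapiens) for inhibition, read by MTT assay, with a stated time of 48 h (a higher number here means a weaker inhibitor, a lower number a stronger inhibitor), compound 1 `O=C(CCCOc1no[n+]([O-])c1S(=O)(=O)c1ccccc1)NO` gives 3830 nM, the lowest number of the three measured, with its steps to both others beyond the scatter. Compound 2 `O=C(COCCOc1no[n+]([O-])c1S(=O)(=O)c1ccccc1)NO` gives 13400 nM and compound 3 `O=C(/C=C/COc1no[n+]([O-])c1S(=O)(=O)c1ccccc1)NO` gives 59900 nM.

Compound 4 `O=C(NO)OCCOCCOc1no[n+]([O-])c1S(=O)(=O)c1ccccc1` is not yet measured. Its difference from compound 1 is 2-((hydroxycarbamoyl)oxy)ethoxy in place of (hydroxycarbamoyl)methyl on a saturated chain carbon, two bonds along the chain from an oxygen on an aromatic ring. The nearest measured change lies at that same place, (hydroxycarbamoyl)methoxy in place of (hydroxycarbamoyl)methyl, and gives a modest step, a 3.5-fold higher number from compound 1 to compound 2 (0.54 log units; beyond the scatter). The large step of a 16-fold higher number from compound 1 to compound 3 (1.19 log units; beyond the scatter) comes from 2-(hydroxycarbamoyl)ethenyl in place of 2-(hydroxycarbamoyl)ethyl, a different chain from the one entering here, so it serves only as a warning of how far the numbers can move. Within the data shown here, no measured compound carries the entering group, which keeps the uncertainty wide.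

In this assay a modest to large step towards a higher number, meaning a weaker inhibitor, is therefore expected. The expected step is a 5.2-fold higher number from compound 1 to compound 4 (0.72 log units; beyond the scatter). For compound 4 the estimated value is 20000 nM, with an expected range of 6000 nM to 60000 nM.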

Compound 4, half-maximal inhibitory concentration: 11700 nM
Beside the measured number, compound 4's estimate is 1.7-fold (0.23 log units) above it; measured number inside the range.
By their numbers in this assay, from the lowest: compound 1; then compounds 4 and 2 (each within the scatter of the next); then compound 3.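

In this assay, the step of a 3.1-fold higher number from compound 1 to compound 4 (0.48 log units; beyond the scatter) falls in the same modest class as the step to compound 2, so at this place, on a saturated chain carbon, two bonds along the chain from an oxygen on an aromatic ring, the larger 2-((hydroxycarbamoyl)oxy)ethoxy group is tolerated to the same degree as (hydroxycarbamoyl)methoxy. The further change of ((hydroxycarbamoyl)oxy)methyl in place of hydroxycarbamoyl gives a 1.1-fold lower number from compound 2 to compound 4 (0.06 log units; within the scatter) and so leaves the number unmoved, which shows that in these two compounds both the extension of the chain and the oxygen attached to the hydroxycarbamoyl group can be present without a separable effect in this assay. No measurement in hand accounts for these steps.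

Still open, going by these compounds, is whether the step away from compound 1 follows the chain oxygen itself, which a longer all-carbon chain ending in hydroxycarbamoyl would test, as would an amine at the place of that oxygen. Also open, on these data alone, is how much of the number in this assay depends on the hydroxycarbamoyl end, which a carboxylic acid in its place would address.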